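Uridine series: from azido to methylamino

A few compounds are considered here, and "the series" means these few. Any claim that something is new, unique, unknown or untested is made for them only; others in the source may bear on it.

Measured in a functional assay on OCI-Ly7 cells (Homo sapiens) for antiproliferative activity, read by WST assay, with a stated time of 3 days; on this read-out higher numbers stand for weaker inhibition and lower numbers for stronger inhibition:
- compound 1 `N#Cc1cc(=O)[nH]c(=O)n1[C@@H]1O[C@H](CO)[C@@H](O)[C@H]1O` gives > 50000 nM as a limit
- compound 2 `O=c1cc(I)n([C@@H]2O[C@H](CO)[C@@H](O)[C@H]2O)c(=O)[nH]1` gives > 50000 nM as a limit
- compound 3 `[N-]=[N+]=Nc1cc(=O)[nH]c(=O)n1[C@@H]1O[C@H](CO)[C@@H](O)[C@H]1O` gives > 50000 nM as a limit

Compound 3 has no number on this read-out, and its > 50000 nM is a limit. The same holds across the set, with the limit of > 50000 nM in this assay, at which 3 of the 3 values shown sit, as the shared result. The next compound to be tested is compound 4 `CNc1cc(=O)[nH]c(=O)n1[C@@H]1O[C@H](CO)[C@@H](O)[C@H]1O`, which carries methylamino in place of azido on an aromatic carbon.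

The measured steps that bear on this change are a step that the two limits leave unreadable from compound 1 to compound 3 and a step that the two limits leave unreadable from compound 2 to compound 3, together with a step that the two limits leave unreadable from compound 1 to compound 2. None of them has a size that can be carried over. What they do show is that cyano, iodo and azido at this place all leave the compound at the limit in this assay. Methylamino has not been measured in this set, so a real gain in compound 4 cannot be ruled out. Among the measured compounds shown here, with no measured step pointing either way, no step beyond the scatter is expected, and a further limit is the likeliest report. The expected outcome is a number no higher from compound 3 to compound 4 (the limit leaves the size open), with no direction favoured. Compound 4 is estimated at 50000 nM, with an expected range from 20000 nM to 100000 nM.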

Compound 4, half-maximal inhibitory concentration: > 50000 nM
Compound 4 was reported as a limit (the forecaster's own chance of this, stated with the estimate: 85%); the middle value sits exactly at the limit.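

In this assay compound 4 gives > 50000 nM, a limit. No new step can be read, as the steps to compound 4 from compound 1, compound 2 and compound 3 all join two limits. The set shares one result: the limit of > 50000 nM in this assay, at which 4 of the 4 values shown sit.

The compounds shown leave open whether any group at this place gives a measurable value in this assay, and how these four compounds rank.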